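Heteroaryl swap on the sulfonamide nitrogen: compound 3

A few compounds are considered here, and "the series" means these few. Any claim that something is new, unique, unknown or untested is made for them only; others in the source may bear on it.

Compound 1 `CCc1ccccc1N(CC(=O)NCc1ccc(Cl)cc1)S(=O)(=O)c1ccc(C)cc1` gives 11.5 nM in a functional assay on CHO-K1 cells for antagonist activity at prostaglandin E2 receptor EP1 subtype (Homo sapiens), read by FLIPR and calcium flux; on this read-out higher numbers stand for weaker inhibition and lower numbers for stronger inhibition. Compound 2 `Cc1ccc(S(=O)(=O)N(CC(=O)NCc2ccc(Cl)cc2)c2cccc(C)n2)cc1` carries 6-methylpyridin-2-yl on the sulfonamide nitrogen. For compound 2 the result in this assay is only a limit, < 1450 nM, so where compound 2 truly stands below that limit is not known. The step that the limit leaves unreadable from compound 1 to compound 2 is unreadable because of the limit (the limit of < 1450 nM in this assay, at which 1 of the 2 values shown sits).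

Compound 3 `Cc1ccc(S(=O)(=O)N(CC(=O)NCc2ccc(Cl)cc2)c2ccnn2C)cc1` differs from compound 2 in one place: 1-methyl-1H-pyrazol-5-yl in place of 6-methylpyridin-2-yl on a sulfonamide nitrogen. Among the compounds with values here, no measured step covers this change; the single step is the unreadable one just described, so it offers neither a size nor a direction for the new pair. The expected step that the limit leaves unreadable from compound 2 to compound 3 is therefore taken as no change beyond the scatter, with wide uncertainty. Compound 3 is expected to give about 500 nM in this assay, within a range of 40 nM to 3000 nM.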

Compound 3, inhibition constant: 589 nM
The estimate for compound 3 lay 1.2-fold (0.07 log units) below the measured number; low and high end bracket the measured number.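

Within the data shown here, compound 3 gives the only readable value for a heteroaromatic ring on the sulfonamide nitrogen in this assay. Exchanging 2-ethylphenyl for 1-methyl-1H-pyrazol-5-yl at this place gives much weaker inhibition, with a 51-fold higher number from compound 1 to compound 3 (1.71 log units; beyond the scatter), so this position does not accept every aromatic ring equally. The steps that involve compound 2 cannot be read, because its value is only a limit: the limit of < 1450 nM in this assay, at which 1 of the 3 values shown sits.

As far as these compounds go, whether the loss belongs to heteroaromatic rings in general stays open, since compound 2 gives no number to test it and compound 3 is the sole readable case. Nor do the compounds shown separate the ring change from the loss of the ethyl group, which a plain phenyl or a cyclohexyl group on the sulfonamide nitrogen could address.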